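The compounds below may be only part of what the source reports. "The series", "measured", "known", "first", "only" and "open" are said of these compounds alone.

Compound 1 `C/C=C/C(=O)Nc1ccc(Cn2nc(-c3ccc(Oc4ccccc4)cc3)cc2CO)cc1` gives the highest number of the three measured compounds in a functional assay on Z-138 cells (Homo sapiens) for inhibition, read by luminescence and CellTiter-Glo, with a stated time of 72 h (a higher number here means a weaker inhibitor, a lower number a stronger inhibitor), where compound 1 gives 54500 nM. Compound 2 `C/C=C/C(=O)Nc1cccc(Cn2nc(-c3ccc(Oc4ccccc4)cc3)cc2C(=O)OCC)c1` shares the phenoxyphenyl-bearing portion but is built on a different core; how the two cores differ is not broken down here. In this assay compound 2 gives 8900 nM. Compound 3 `C=CC(=O)Nc1cccc(Cn2nc(-c3ccc(Oc4ccccc4)cc3)cc2C(=O)OCC)c1` differs from compound 2 by vinyl in place of prop-1-en-1-yl on a carbonyl carbon, and in this assay compound 3 gives 7800 nM. That change made a 1.1-fold lower number from compound 2 to compound 3 (0.06 log units; within the scatter).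

Compound 4 `C=CC(=O)Nc1ccc(Cn2nc(-c3ccc(Oc4ccccc4)cc3)cc2CO)cc1` is not yet measured. It stands to compound 1 as compound 3 stands to compound 2: the change is vinyl in place of prop-1-en-1-yl on a carbonyl carbon, at the same place in both pairs, so it is the same change. Among the compounds with values here, since the only measured instance of this change gave a 1.1-fold lower number from compound 2 to compound 3 (0.06 log units; within the scatter), the step from compound 1 to compound 4 in this assay is expected to be about as small, a 1.1-fold lower number from compound 1 to compound 4 (0.04 log units; within the scatter), on the basis of that single pair alone. Compound 4 is therefore estimated at 50000 nM in this assay, with a plausible range from 25000 nM to 100000 nM.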

Compound 4, half-maximal inhibitory concentration: 6800 nM
The estimate for compound 4 lay 7.4-fold (0.87 log units) above the measured number; measured number outside the range, below it.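

In this assay, vinyl in place of prop-1-en-1-yl on the carbonyl carbon gave an 8.0-fold lower number from compound 1 to compound 4 (0.90 log units; beyond the scatter), a step of a different size from the one seen on the other core. The size of the step thus did not carry over from one core to the other: the same change on two cores in this assay, a 1.1-fold lower number (0.06 log units; within the scatter) from compound 2 to compound 3 and an 8.0-fold lower number (0.90 log units; beyond the scatter) from compound 1 to compound 4, 7.0-fold (0.85 log units) apart, beyond the scatter of two such steps. Within the data shown here, with only one pair on each core, this shows that the result of the change can depend on the core that carries it, but it does not show which difference between the cores matters, nor what size of step to expect on a further core.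

The compounds shown leave open how the same change would read on a core carrying a carboxylic acid or an amine. They also leave open whether a longer chain than prop-1-en-1-yl on the same carbonyl carbon would give a number closer to that of compound 1 or to that of compound 4.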